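The source may report more compounds than this note shows. Statements on the series, on what has been measured and on what is new or still open speak of the compounds shown alone.

Compound 1 `O=C1CCC(N2C(=O)c3ccc(Nc4ccc(O)cc4)cc3C2=O)C(=O)N1` gives 4%.
Compound 2 `O=C1CCC(N2C(=O)c3ccc(Nc4ccccn4)cc3C2=O)C(=O)N1` gives 9%.
Compound 3 `O=C1CCC(N2C(=O)c3cccc(Nc4ccc(O)cc4)c3C2=O)C(=O)N1` gives 4%.

All three were tested in an assay on FRT-Jurkat cells for inhibition of nuclear factor NF-kappa-B complex (Homo sapiens), read by flow cytometry, with a stated time of 24 h, tested at 10 uM; on this read-out higher numbers stand for more inhibition at the one concentration tested (going by the name of the read-out) and lower numbers for less inhibition. On these numbers compound 2 cannot be told apart from its neighbours: the step of a number 5 percentage points higher from compound 1 to compound 2 (within the scatter) lies within the scatter, and the value of compound 3 sits the same small distance from compound 2, so the three numbers read as level at the single concentration tested.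

Compound 4 `CC(C)c1ccc(Nc2ccc3c(c2)C(=O)N(C2CCC(=O)NC2=O)C3=O)cc1` has not yet been measured. It differs from compound 2 in one place: 4-isopropylphenyl in place of pyridin-2-yl on a nitrogen on an aromatic ring. Among the compounds with values here, the only measured step that touches this position is a number 5 percentage points higher from compound 1 to compound 2 (within the scatter), where one aromatic ring on that nitrogen was swapped for another without a change beyond the scatter. Within the data shown here, nothing measured so far shows that varying the ring on that nitrogen moves the read-out, so for compound 4 a step of about a number 1 percentage points lower from compound 2 to compound 4 (within the scatter) is expected, that is, none beyond the scatter. Compound 4 is therefore estimated to give 8%, with a likely range from -5% to 22%.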

Compound 4, a percentage reported as inhibition, at one concentration (the size of the read-out at that concentration, not a potency): 11%
Estimate against measurement, compound 4: 3 percentage points below; low and high end bracket the measured number.
By their numbers in this assay, from the lowest: compounds 1, 3, 2 and 4 (each within the scatter of the next).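

Within the data shown here, the swap to 4-isopropylphenyl in this assay reads as a number 2 percentage points higher from compound 2 to compound 4 (within the scatter) even though the entering ring is carbon only, has no hydrogen-bond acceptor and carries more heavy atoms than pyridin-2-yl, so on this nitrogen the read-out stays level through a larger change of ring than the earlier compounds covered. Compound 4 also gives a second comparison at this position, since isopropyl in place of hydroxy on an aromatic carbon of the ring amounts to a number 7 percentage points higher from compound 1 to compound 4 (within the scatter) and a hydroxy group and an isopropyl group therefore cannot be told apart here. No evidence on what lies behind these numbers is available.

All of the groups shown on this nitrogen are aromatic rings, and every one of them stays within the scatter of the others, so the compounds give no group that moves the read-out clearly. Whether an open alkyl chain on the nitrogen, or a carboxylic acid or an amine on the ring, would shift the inhibition beyond the scatter remains an open question.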